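Phenyl for Thiophenyl on a Pyridine-Free Core Comparison

A few compounds are considered here, and "the series" means these few. Any claim that something is new, unique, unknown or untested is made for them only; others in the source may bear on it.

Compound 1 `Oc1ccc(-c2cc(-c3ccccc3)nc(-c3ccccc3Cl)c2)cc1`: 3930 nM
Compound 2 `Oc1cccc(-c2cc(-c3ccccc3)nc(-c3cccc(Cl)c3)c2)c1`: 3120 nM
Compound 3 `Oc1ccc(-c2cc(-c3cccc(Cl)c3)nc(-c3cccs3)c2)cc1`: 2720 nM

In an ADME assay on HEK293 cells (Homo sapiens) for cytotoxicity, read by CCK-8 assay and cell counting, with a stated time of 2 days (on this read-out higher numbers stand for weaker inhibition and lower numbers for stronger inhibition), the three measured compounds sit close together. Compound 3 shows the lowest of the three numbers, yet its gaps to compound 2 and to compound 1 both stay within the scatter, so no ordering among them can be read.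

Compound 4 `Oc1ccc(-c2cc(-c3ccccc3)nc(-c3cccc(Cl)c3)c2)cc1` is the next compound. It differs from compound 3 in one place: phenyl in place of thiophen-2-yl on an aromatic carbon.

Among the measured compounds shown here, no step between measured compounds is available for this kind of exchange, so the expected step can only rest on how tightly the measured values cluster. Compound 4 is therefore expected to show a 1.2-fold higher number from compound 3 to compound 4 (0.08 log units; within the scatter), a step of no clear direction and no larger than the scatter. Compound 4 is estimated at 3300 nM, within a range from 1800 nM to 6500 nM.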

Compound 4, half-maximal inhibitory concentration: 2820 nM
Compound 4: the middle estimate sits 1.2-fold (0.07 log units) above what was measured, and the stated range covers the measured number.
By their numbers in this assay, from the lowest: compounds 3, 4, 2 and 1 (each within the scatter of the next).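

In this assay the aromatic carbon next to the ring nitrogen accepts phenyl in place of thiophen-2-yl with no readable effect, the exchange giving a 1.0-fold higher number from compound 3 to compound 4 (0.02 log units; within the scatter) on the shared core. The two other exchanges also stay within the scatter: 4-hydroxyphenyl in place of 3-hydroxyphenyl gives a 1.1-fold lower number from compound 2 to compound 4 (0.04 log units; within the scatter) and 3-chlorophenyl in place of 2-chlorophenyl gives a 1.4-fold lower number from compound 1 to compound 4 (0.14 log units; within the scatter) as the last step. No further measurement bears on these results. Whether an amine or a carboxylic acid at this position would shift the number beyond the scatter remains open, since all the compounds shown carry aromatic rings there.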